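Hydroxy analogue of the ketone compound 2

The source may hold more compounds than are shown below. What is called first, only, known or untested is meant among the compounds shown, and "the series" means these compounds.

- compound 1 `CCn1c(C(=O)N(CCC#N)CCC#N)ccc1C(CC)(CC)c1ccc(OCC(O)C(C)(C)C)c(C)c1` gives 7800 nM
- compound 2 `CCn1c(C(=O)N(C)CC(=O)O)ccc1C(CC)(CC)c1ccc(OCC(=O)C(C)(C)C)c(C)c1` gives 18400 nM

In a functional assay on PC-3 cells (Homo sapiens), read by MTT assay, with a stated time of 48 h (on this read-out lower numbers stand for stronger inhibition and higher numbers for weaker inhibition), compound 2 (18400 nM) has the higher of the two numbers, and the gap to compound 1 lies beyond the usual scatter. Compound 3 `CCn1c(C(=O)N(C)CC(=O)O)ccc1C(CC)(CC)c1ccc(OCC(O)C(C)(C)C)c(C)c1` carries 1-hydroxy-2,2-dimethylpropyl in place of (tert-butyl)carbonyl on a saturated chain carbon bound to an oxygen on an aromatic ring. Compound 1 (7800 nM) also bears 2-hydroxy-3,3-dimethylbutoxy, but its amide differs as well, so the data do not isolate this change. A small expected shift towards lower numbers, possibly none beyond the scatter, is estimated (a 1.3-fold lower number from compound 2 to compound 3 (0.12 log units; within the scatter)). For compound 3 the estimated value is 14000 nM (range 6000 nM to 32000 nM).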

Compound 3, half-maximal inhibitory concentration: 23900 nM
For compound 3 the middle estimate is 1.7-fold (0.23 log units) below the measured one, and the stated range covers the measured number.
By their numbers in this assay, from the lowest: compound 1; then compounds 2 and 3 (each within the scatter of the next).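

In this assay, the exchange of (tert-butyl)carbonyl for 1-hydroxy-2,2-dimethylpropyl on a saturated chain carbon bound to an oxygen on an aromatic ring gives a 1.3-fold higher number from compound 2 to compound 3 (0.11 log units; within the scatter), so the ketone and the alcohol are not told apart at this position. With the alcohol held constant, the amide change can now be read alone and gives a 3.1-fold higher number from compound 1 to compound 3 (0.49 log units; beyond the scatter). Nothing available bears on the reason for either step. Open, on these data alone, is whether an amine or a longer chain at this position would shift the number, and whether the amide step also holds with the ketone.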